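This account rests on a few compounds, and the source may have more. Where it says the series, first, only, none or still open, it means among the compounds named here.

Compound 2 `CC(C)=C1C(=O)Nc2ccc(OCc3cccc(C)c3)cc21` stands without a number in an assay on cells for inhibition of Amine oxidase [flavin-containing] B (Homo sapiens), read by fluorescence, with stated times of 30 min and 15 min, tested at 1 uM; a higher number here means more inhibition at the concentration tested (going by the name of the read-out), a lower number less inhibition: there compound 2 is reported as "not active" (no number reported). Compound 3 `CC1(C)C(=O)Nc2ccc(OCCOc3ccccc3)cc21` carries the same report, being given in this assay as "not active" (no number reported). The sole figure in the set belongs to compound 1 `Cn1c(=O)[nH]c2ccc(OCc3cccc(F)c3)cc21`, which in this assay gives 5.36%. Compound 4 `CC(C)=C1C(=O)Nc2ccc(OCc3cccc(F)c3)cc21` has not been measured. Compound 4 differs from compound 2 by fluoro in place of methyl on an aromatic carbon. Among the compounds with values here, no measured pair shows this exchange, so its effect cannot be read from the data; because compound 1 gives 5.36% and compound 2 is reported inactive, no step beyond the scatter in this assay is expected in either direction. Compound 4 is therefore estimated at 5%, with a range from -5% to 15%, and it may well be reported only as not active.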

Compound 4, a percentage reported as inhibition, at one concentration (the size of the read-out at that concentration, not a potency): "not active" (no number reported)
Compound 4: no number reported; the estimate stays without a comparison.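

Compound 2 and compound 4 both stand without a number in this assay and no step can be read between them; nothing given here offers an explanation for this result. The compounds shown leave open whether fluoro in place of methyl alters inhibition at all.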